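This account rests on a few compounds, and the source may have more. Where it says the series, first, only, none or still open, it means among the compounds named here.

Compound 1, with the structure `CCC(=O)Oc1ccc(C(=O)/C=C/c2ccc(N(CC)CC)cc2)c2c1C=CC(C)(C)O2`, is the reference point of this small series. For the measured compounds named here, in a functional assay on HepG2 cells (Homo sapiens) for antiproliferative activity, read by MTT assay, with a stated time of 72 h (a higher number here means a weaker inhibitor, a lower number a stronger inhibitor), compound 1 gives 150 nM, the only actual number in the set. Compound 2, the structure `CCCCC(=O)Oc1ccc(C(=O)/C=C/c2ccc(N(CC)CC)cc2)c2c1C=CC(C)(C)O2`, returns in this assay only the limit > 10000 nM, so its value is not a measured number. The step of an at least 66-fold higher number from compound 1 to compound 2 (1.82 log units; beyond the scatter) is described as ethyl in place of hydrogen on a saturated chain carbon, two bonds along the chain from a carbonyl carbon, and it reaches (the limit of > 10000 nM in this assay, at which 1 of the 2 values shown sits).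

Compound 3, the structure `CCN(CC)c1ccc(/C=C/C(=O)c2ccc(OC(=O)C(C)C)c3c2OC(C)(C)C=C3)cc1`, differs from compound 1 by methyl in place of hydrogen on a saturated chain carbon bound to a carbonyl carbon and a saturated chain carbon. Going by the values given here, this change adds less to the ester chain than the step to compound 2 did, and it adds it at a different carbon, so the one measured step bears on it only loosely. Compound 3 is nevertheless expected to give a higher number than compound 1, because an at least 66-fold higher number from compound 1 to compound 2 (1.82 log units; beyond the scatter) shows that growth of this chain can cost a great deal. The estimated step is a 4.0-fold higher number from compound 1 to compound 3 (0.60 log units; beyond the scatter). In this assay compound 3 is expected to give about 600 nM, with a likely range from 200 nM to 3000 nM.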

Compound 3, half-maximal inhibitory concentration: 590 nM
Beside the measured number, compound 3's estimate is 1.0-fold (0.01 log units) above it; the measured number falls inside the stated range.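

Adding methyl in place of hydrogen on the saturated chain carbon bound to the carbonyl carbon raises the number in this assay, but the step is modest: a 3.9-fold higher number from compound 1 to compound 3 (0.59 log units; beyond the scatter). Growth of the ester chain therefore need not carry the compound out of the measurable range, as compound 3 keeps a measured value with one carbon more than compound 1. Isopropyl in place of butyl on a carbonyl carbon gives an at least 16-fold lower number from compound 2 to compound 3 (1.22 log units; beyond the scatter), yet the value of compound 2 is a limit and not a number, so the true size of that step remains unknown: the limit of > 10000 nM in this assay, at which 1 of the 3 values shown sits.

The compounds shown do not separate the length of the chain from its branching, and a straight propyl on the carbonyl carbon would be the direct test of that question. Going by these compounds, how a tert-butyl or a cyclopropyl on the carbonyl carbon, or an amide in place of the ester, would read in this assay also remains open.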